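A few compounds are considered here, and "the series" means these few. Any claim that something is new, unique, unknown or untested is made for them only; others in the source may bear on it.

Compound 1 `CC(CCCC(=O)O)c1cccc(OCc2ccc3ccccc3n2)c1` gives 500 nM in a functional assay (lung) for inhibition, with Cavia porcellus as the target; a higher number here means a weaker inhibitor, a lower number a stronger inhibitor. Compound 3 `O=C(O)CCCOc1ccc(OCc2ccc3ccccc3n2)cc1` gives 800 nM in this assay, and compound 2 `c1ccc2nc(COc3ccc(OCCCc4nnn[nH]4)cc3)ccc2c1` gives 250 nM in this assay. The difference between the cores of compound 1 and compound 3 is not broken down here. From compound 3 to compound 2 the change is 1H-tetrazol-5-yl in place of carboxy on a saturated chain carbon, three bonds along the chain from an oxygen on an aromatic ring, and it made the step of a 3.2-fold lower number from compound 3 to compound 2 (0.51 log units; beyond the scatter). Compound 4 `CC(CCCc1nnn[nH]1)c1cccc(OCc2ccc3ccccc3n2)c1` carries the same kind of change relative to compound 1, (1H-tetrazol-5-yl in place of carboxy on a saturated chain carbon, four bonds along the chain from an aromatic carbon); the surroundings differ, the group now sitting four bonds along the chain from an aromatic carbon instead of three bonds along the chain from an oxygen on an aromatic ring. For compound 4 a step of similar size, a 2.8-fold lower number from compound 1 to compound 4 (0.44 log units; beyond the scatter), is expected, because a 3.2-fold lower number from compound 3 to compound 2 (0.51 log units; beyond the scatter) went beyond the scatter. Compound 4 is estimated at 180 nM, expected between 80 nM and 400 nM.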

Compound 4, half-maximal inhibitory concentration: 250 nM
Beside the measured number, compound 4's estimate is 1.4-fold (0.14 log units) below it; low and high end bracket the measured number.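

Putting 1H-tetrazol-5-yl in place of carboxy on the core of compound 1 gives a 2.0-fold lower number from compound 1 to compound 4 (0.30 log units; within the scatter) in this assay. Set beside the earlier step, the change cannot be told apart between the two cores: the same change on two cores in this assay, a 3.2-fold lower number (0.51 log units; beyond the scatter) from compound 3 to compound 2 and a 2.0-fold lower number (0.30 log units; within the scatter) from compound 1 to compound 4, 1.6-fold (0.20 log units) apart, within the scatter of two such steps. This agreement fits the change carrying over between these two cores, but the step on the core of compound 1 does not by itself establish a gain, and two pairs in one assay show nothing about any other core.

The compounds shown leave open whether a sulfonamide or a hydroxamic acid in the same place would give a similar step. They also leave open how a longer chain bearing the 1H-tetrazol-5-yl group would read.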